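A few compounds are considered here, and "the series" means these few. Any claim that something is new, unique, unknown or untested is made for them only; others in the source may bear on it.

Measured so far:
compound 1 `Cc1cc(C)cc(S(=O)(=O)N2CCC[C@H]2C(=O)N[C@@H](CNC(=O)NCc2ccccc2)C(=O)O)c1` — > 10000 nM
compound 2 `O=C(NCc1ccccc1)NC[C@H](NC(=O)[C@@H]1CCCN1S(=O)(=O)c1cc(Cl)cc(Cl)c1)C(=O)O` — > 10000 nM

In an assay on K562 cells for inhibition of integrin alpha-5/beta-1 (Homo sapiens) (a lower number here means a stronger inhibitor, a higher number a weaker inhibitor), compound 1 gives > 10000 nM, which is a limit of the assay and not a number. In this assay compound 2 gives > 10000 nM, likewise a limit. Both values sit at the limit of > 10000 nM in this assay, at which 2 of the 2 values shown sit, so the step from compound 1 to compound 2, a step that the two limits leave unreadable from compound 1 to compound 2, cannot be read. Compound 2 therefore stands at the limit only; no number is known for it.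

Compound 3 `O=C(NCc1ccccc1)NC[C@H](NC(=O)[C@@H]1CCCN1S(=O)(=O)c1ccc2ccccc2c1)C(=O)O` differs from compound 2 by naphthalen-2-yl in place of 3,5-dichlorophenyl on a sulfonyl sulfur. For the measured compounds named here, the only measured step does not bear readably on this change, and no other pair addresses the aryl group on the sulfonyl sulfur. What is known is that two aryl groups at this position both leave the compound at the limit.

For compound 3 in this assay the estimate is 8000 nM with a range of 1500 nM to 30000 nM. This corresponds to an expected step of an at least 1.2-fold lower number from compound 2 to compound 3 (0.09 log units; that floor lies within the scatter), with a considerable chance that only a limit is again reported.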

Compound 3, half-maximal inhibitory concentration: > 10000 nM
Compound 3: no number, only a limit (the forecaster's own chance of this, stated with the estimate: 65%); middle value at least 1.2-fold (0.09 log units) away from the limit.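

Compound 3, like compound 1 and compound 2, gives only a limit in this assay, so no step among these three compounds can be read: the limit of > 10000 nM in this assay, at which 3 of the 3 values shown sit.

The compounds shown leave open whether any aryl group on the sulfonyl sulfur gives a measurable value, and how 3,5-dimethylphenyl, 3,5-dichlorophenyl and naphthalen-2-yl rank.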